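The compounds below may be only part of what the source reports. "The series", "measured", "known", "first", "only" and "open" are said of these compounds alone.

Of the compounds shown here, three sharing one core have been read in an ADME assay on BE(2)-C cells (Homo sapiens) for cytotoxicity, read by MTT assay, with a stated time of 20 h; on this read-out higher numbers stand for lower toxicity in this test and lower numbers for higher toxicity in this test. Compound 1 (`CC(NC(=O)C1CCN(C(=O)c2cc3ccccc3n2Cc2ccc(Cl)cc2)CC1)c1ccncc1`) gives 90100 nM. Compound 2 (`C[C@@H](NC(=O)C1CCN(C(=O)c2cc3ccccc3n2Cc2ccc(Cl)cc2)CC1)c1ccncc1`), drawn with a defined configuration at its stereocentre, gives 92300 nM, and the measured step is a 1.0-fold higher number from compound 1 to compound 2 (0.01 log units; within the scatter). Compound 3 (`CN(C)C(=O)C1CCN(C(=O)c2cc3ccccc3n2Cc2ccc(Cl)cc2)CC1`) gives > 100000 nM, which is a limit of this assay and not a number.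

Compound 4 (`O=C(c1cc2ccccc2n1Cc1ccc(Cl)cc1)N1CCC(C(=O)N2CCCC2)CC1`) has not yet been measured. It carries pyrrolidin-1-yl in place of dimethylamino on a carbonyl carbon. Going by the values given here, the steps that bear on this change are those at the same carbonyl carbon, where dimethylamino replaces (1-(pyridin-4-yl)ethyl)amino: an at least 1.1-fold higher number from compound 1 to compound 3 (0.04 log units; that floor lies within the scatter) and an at least 1.0-fold higher number from compound 2 to compound 3 (0.03 log units; that floor lies within the scatter). Both are floors within the scatter, so neither shows a change of measurable size at this place. No step beyond the scatter, in either direction, is therefore expected in this assay. The expected step is a number no higher from compound 3 to compound 4 (the limit leaves the size open). For compound 4 the estimated value is 100000 nM, with an expected range from 60000 nM to 170000 nM.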

Compound 4, half-maximal cytotoxic concentration: 65600 nM
Compound 4: middle estimate off by 1.5-fold (0.18 log units), on the high side; the measured number falls inside the stated range.
By their numbers in this assay, from the lowest: compounds 4, 1 and 2 (each within the scatter of the next). At a limit, above all of these: compound 3.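

At this carbonyl carbon, pyrrolidin-1-yl gives a number where dimethylamino gave none, and the step is an at least 1.5-fold lower number from compound 3 to compound 4 (0.18 log units; that floor lies within the scatter). Going by these compounds, that step is only a floor, and its size stays open: the limit of > 100000 nM in this assay, at which 1 of the 4 values shown sits. Against the (1-(pyridin-4-yl)ethyl)amino compounds in this assay, the steps are a 1.4-fold lower number from compound 2 to compound 4 (0.15 log units; within the scatter) and a 1.4-fold lower number from compound 1 to compound 4 (0.14 log units; within the scatter), so exchanging that group for pyrrolidin-1-yl produces no change of measurable size.

The compounds shown leave open whether any group at this carbonyl carbon, such as a morpholin-4-yl, a piperidin-1-yl or a carboxylic acid, would move the number beyond the scatter. They also do not tell how far the true number of compound 3 lies from its limit.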